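Benzofurazan dioxide amines: nitro on the benzyl ring

A few compounds are considered here, and "the series" means these few. Any claim that something is new, unique, unknown or untested is made for them only; others in the source may bear on it.

Measured compounds:
compound 1 `C=CCNc1n[n+]([O-])c2ccccc2[n+]1[O-]` — 11200 nM
compound 2 `[O-][n+]1nc(NCc2ccccc2)[n+]([O-])c2ccccc21` — 1900 nM

Going by the values given here, compound 2 gives the lower of the two numbers in a functional assay on K562 cells (Homo sapiens) for cytotoxicity, read by MTT assay, with a stated time of 48 h; a higher number here means a weaker inhibitor, a lower number a stronger inhibitor; the only neighbour is compound 1, which in this assay gives 11200 nM, and the one measured step is a 5.9-fold lower number from compound 1 to compound 2 (0.77 log units; beyond the scatter), a phenyl in place of vinyl on a saturated chain carbon bound to a nitrogen on an aromatic ring. Compound 3 `O=[N+]([O-])c1ccc(CNc2n[n+]([O-])c3ccccc3[n+]2[O-])cc1` keeps the benzyl arm of compound 2 and differs by nitro in place of hydrogen on an aromatic carbon, the nitro sitting on an aromatic carbon of the six-membered carbon ring, para to a large group.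

Among the compounds with values here, no measured step touches a substituent on that ring, so the step from compound 1 to compound 2 gives no direct bearing on this change; it shows only that the series tolerates change at the arm beyond the scatter. With nothing closer to lean on, compound 3 is expected to give a step of a 1.3-fold lower number from compound 2 to compound 3 (0.10 log units; within the scatter), that is, none beyond the scatter. Compound 3 is therefore estimated at 1500 nM in this assay, with a range of 450 nM to 5000 nM.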

Compound 3, half-maximal inhibitory concentration: 3100 nM
Compound 3: the middle estimate sits 2.1-fold (0.32 log units) below what was measured; low and high end bracket the measured number.
By their numbers in this assay, from the lowest: compounds 2 and 3 (each within the scatter of the next); then compound 1.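

In this assay, the nitro substitution on the six-membered aromatic ring of carbon only gives a 1.6-fold higher number from compound 2 to compound 3 (0.21 log units; within the scatter) and so leaves compound 3 and compound 2 indistinguishable. Going by these compounds alone, this is the first reading at a place on that ring, para to a large group, and it shows that nitro can stand there in place of hydrogen with no change beyond the scatter, whereas the earlier change at the arm gave a 5.9-fold lower number from compound 1 to compound 2 (0.77 log units; beyond the scatter) and lay beyond it. Nothing at hand bears on why this substitution and the change at the arm read so differently.

Going by these compounds, one group at one place does not describe this position as a whole, so it remains open whether an amine, a methoxy group or a chlorine atom in the same place would also stay within the scatter of compound 2. Also open, on these data alone, are the reading for nitro on another carbon of that ring and the effect of a longer chain linking the ring to the nitrogen on the shared core.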